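Selenium for sulfur on the shared core

A few compounds are considered here, and "the series" means these few. Any claim that something is new, unique, unknown or untested is made for them only; others in the source may bear on it.

Measured compounds in a functional assay on PC-3 cells (Homo sapiens) for cytotoxicity, read by MTT assay; a lower number here means a stronger inhibitor, a higher number a weaker inhibitor:
compound 1 `CS/C(=N\C(=O)c1ccc(Cl)nc1)NC(=O)c1ccc(Cl)nc1` — > 10000 nM
compound 2 `CS/C(=N\C(=O)c1ccccc1)NC(=O)c1ccccc1` — > 10000 nM

In this assay compound 1 gives > 10000 nM, which is a limit of the assay and not a number. In this assay compound 2 gives > 10000 nM, likewise only a limit. Compound 2 therefore stands at the limit itself, the point at which both values shown sit (the limit of > 10000 nM in this assay, at which 2 of the 2 values shown sit). Within the data shown here, no step between measured compounds can be taken from these two, as neither is a number.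

Compound 3 `C[Se]/C(=N\C(=O)c1ccccc1)NC(=O)c1ccccc1` differs from compound 2 by a single exchange: a group of 2 heavy atoms (1 carbon, 1 selenium; no ring) in place of a group of 2 heavy atoms (1 carbon, 1 sulfur; no ring), on a carbon with a double bond to nitrogen, on the carbon with a double bond to nitrogen whose other neighbours are both amide-type nitrogens. The measured compounds carry no information on this exchange, and the only point of reference, compound 2, is a limit. The expectation is that compound 3 remains near the limit, with some chance of a measurable number. The step expected is an at least 1.2-fold lower number from compound 2 to compound 3 (0.09 log units; that floor lies within the scatter). For compound 3 the estimate in this assay is 8000 nM, with a range from 1500 nM to 40000 nM.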

Compound 3, half-maximal inhibitory concentration: 2500 nM
The estimate for compound 3 lay 3.2-fold (0.51 log units) above the measured number; the range from low to high includes it.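

Selenium in place of sulfur, on the carbon with a double bond to nitrogen whose other neighbours are both amide-type nitrogens, gives the series its first measurable number in this assay, with an at least 4.0-fold lower number from compound 2 to compound 3 (0.60 log units; beyond the scatter). Compound 1 and compound 2 could not show that this position affects the read-out, whereas the methylsulfanyl exchange in compound 3 shows that a change of one atom here is enough to bring the shared core within the measurable range of this assay. The true size of the step remains unknown and can be stated only as a floor, because compound 2 has only a limit and not a number: the limit of > 10000 nM in this assay, at which 2 of the 3 values shown sit.

Going by these compounds, it remains open whether the same exchange on the core of compound 1, with its chlorine-bearing rings, would also give a measurable number, and so whether the effect carries over to other aryl groups. Also open, on these data alone, is what a longer chain on the selenium, such as ethyl or benzyl, or an amine in place of the selenium-bearing group, would do at this position.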